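The compounds below may be only part of what the source reports. "The series", "measured", "known", "first", "only" and "open" are said of these compounds alone.

In a functional assay on MCF7 cells (Homo sapiens) for inhibition, read by MTT assay, with a stated time of 72 h (a higher number here means a weaker inhibitor, a lower number a stronger inhibitor), compound 1 (`COc1ccc(-c2nnc(SCCCN3CCN(c4nc5ccccc5s4)CC3)o2)cc1`) gives 171000 nM and compound 2 (`Cc1ccc(-c2nnc(SCCCN3CCN(c4nc5ccccc5s4)CC3)o2)cc1`) gives 107000 nM and so stands within the usual scatter of compound 1. Compound 3 (`Clc1ccc(-c2nnc(SCCCN3CCN(c4nc5ccccc5s4)CC3)o2)cc1`) has chloro in place of methyl on an aromatic carbon, para to a large group. Going by the values given here, only one measured step bears on this, methyl in place of methoxy (a 1.6-fold lower number from compound 1 to compound 2 (0.20 log units; within the scatter)), and it stayed within the scatter. No step beyond the scatter is therefore expected in this assay for this change. The expected step is small (a 1.1-fold lower number from compound 2 to compound 3 (0.03 log units; within the scatter)). Compound 3 is estimated at 100000 nM with a range of 45000 nM to 220000 nM as the expected span.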

Compound 3, half-maximal inhibitory concentration: 116000 nM
Compound 3: the middle estimate sits 1.2-fold (0.06 log units) below what was measured; the range from low to high includes it.
By their numbers in this assay, from the lowest: compounds 2, 3 and 1 (each within the scatter of the next).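

In this assay, the change from 4-methylphenyl to 4-chlorophenyl gives a 1.1-fold higher number from compound 2 to compound 3 (0.04 log units; within the scatter) and chloro in place of methoxy gives a 1.5-fold lower number from compound 1 to compound 3 (0.17 log units; within the scatter) at the same aromatic carbon. Where the earlier pair compared only methoxy and methyl, three groups at this position now read alike within the scatter. Nothing available explains this sameness. From the compounds shown here alone, whether an amine or a carboxylic acid on this carbon would shift the number beyond the scatter stays open. So does whether a change elsewhere in the shared core would matter more.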